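The source may report more compounds than this note shows. Statements on the series, on what has been measured and on what is new or still open speak of the compounds shown alone.

Compound 1 `O=S(=O)(/C=C/c1ccccc1)Cc1ccc(Nc2ncnc3ccccc23)cc1` carries an unsubstituted phenyl on the double-bonded chain carbon; in a functional assay on UACC-62 cells (Homo sapiens) (on this read-out lower numbers stand for stronger inhibition of growth and higher numbers for weaker inhibition of growth), compound 1 reaches only a limit, > 100000 nM, so its standing rests on a limit rather than a number (the limit of > 100000 nM in this assay, at which 1 of the 3 values shown sits). Compound 2 `O=S(=O)(/C=C/c1ccc(F)cc1)Cc1ccc(Nc2ncnc3ccccc23)cc1` gives 5000 nM and compound 3 `O=S(=O)(/C=C/c1ccc(Cl)cc1)Cc1ccc(Nc2ncnc3ccccc23)cc1` gives 13000 nM. Both steps from compound 1 go downward: an at least 20-fold lower number from compound 1 to compound 2 (1.30 log units; beyond the scatter), and an at least 7.6-fold lower number from compound 1 to compound 3 (0.88 log units; beyond the scatter). Compound 4 `O=S(=O)(/C=C/c1ccc(C(F)(F)F)cc1F)Cc1ccc(Nc2ncnc3ccccc23)cc1` differs from compound 1 by 2-fluoro-4-(trifluoromethyl)phenyl in place of phenyl on a double-bonded chain carbon bound to a double-bonded chain carbon. Since both halogen substitutions on that phenyl lowered the number, and fluoro appears again in the entering group together with trifluoromethyl, a further lowering of the number from compound 1 to compound 4 is expected, of about an at least 20-fold lower number from compound 1 to compound 4 (1.30 log units; beyond the scatter). Compound 4 is therefore estimated at 5000 nM, within 1500 nM to 20000 nM.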

Compound 4, concentration for 50% growth inhibition: 100000 nM
Estimate against measurement, compound 4: 20-fold (1.30 log units) below; measured number outside the range, above it.
By their numbers in this assay, from the lowest: compound 2; then compound 3; then compound 4.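

In this assay, 2-fluoro-4-(trifluoromethyl)phenyl in place of 4-fluorophenyl gives a 20-fold higher number from compound 2 to compound 4 (1.30 log units; beyond the scatter), and in place of 4-chlorophenyl it gives a 7.7-fold higher number from compound 3 to compound 4 (0.89 log units; beyond the scatter). The outcome at this position therefore depends on which group enters, not merely on replacing hydrogen. Against the phenyl of compound 1 the data show only a number no higher from compound 1 to compound 4 (the limit leaves the size open), and the size of this step cannot be read, as compound 1 stands at a limit: the limit of > 100000 nM in this assay, at which 1 of the 4 values shown sits.

Going by these compounds, the fluoro and trifluoromethyl enter together in compound 4, so their separate contributions stay open. Also open, on these data alone, is how an amine or a carboxylic acid on that phenyl would behave.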